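A few compounds are considered here, and "the series" means these few. Any claim that something is new, unique, unknown or untested is made for them only; others in the source may bear on it.

Measured so far:
- compound 1, `COc1cccc(-c2cc(O)c3c(C)cc(C)nc3n2)c1`: 288 nM
- compound 2, `COc1ccccc1-c1cc(O)c2cccnc2n1`: 31600 nM
- compound 3, `COc1cccc(-c2cc(O)c3c(C)ccnc3n2)c1`: 22.4 nM

In a functional assay on SK-MEL-5 cells (Homo sapiens) (a higher number here means a weaker inhibitor of growth, a lower number a stronger inhibitor of growth), compound 3 gives 22.4 nM and is the strongest growth inhibitor of the three, its steps to both others lying beyond the scatter. Compound 2 gives 31600 nM in this assay and stands highest of the three numbers; the difference between its core and the core of compound 3 is not broken down here, the two differing in more than one place.

For the measured compounds named here, the one counted step among the measured compounds is a 13-fold higher number from compound 3 to compound 1 (1.11 log units; beyond the scatter), the change being (methyl in place of hydrogen on an aromatic carbon). The same kind of change is now made from compound 2 to compound 4, `COc1ccccc1-c1cc(O)c2cc(C)cnc2n1`: methyl in place of hydrogen on an aromatic carbon. The place is not the same word for word: in the step from compound 3 to compound 1 the methyl enters next to the ring nitrogen and meta to a methyl group, whereas in compound 4 it enters two atoms from the ring nitrogen, and the core carrying it is that of compound 2, not compound 3. With a single precedent, on a different core and at a differently described place, the direction of the step is taken from it only loosely.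

Going by the values given here, the step from compound 2 to compound 4 in this assay is expected to be a 1.4-fold higher number from compound 2 to compound 4 (0.15 log units; within the scatter), smaller than the one from compound 3 to compound 1 because that step, a 13-fold higher number from compound 3 to compound 1 (1.11 log units; beyond the scatter), sits next to the ring nitrogen. For compound 4 the estimate is 45000 nM, with a range from 9000 nM to 160000 nM.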

Compound 4, concentration for 50% growth inhibition: 20400 nM
The estimate for compound 4 lay 2.2-fold (0.34 log units) above the measured number; measured number inside the range.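

In this assay the methyl step on the core of compound 2 reads a 1.5-fold lower number from compound 2 to compound 4 (0.19 log units; within the scatter), so compound 2 and compound 4 cannot be told apart on this read-out. The same named change therefore does not carry a single size from one core to the other in this series, and a large step on one core gives no reliable estimate of the step on another: the same change on two cores in this assay, a 13-fold higher number (1.11 log units; beyond the scatter) from compound 3 to compound 1 and a 1.5-fold lower number (0.19 log units; within the scatter) from compound 2 to compound 4, 20-fold (1.30 log units) apart, beyond the scatter of two such steps

What this does not show is the source of the gap: the two steps differ in both the core and the place of the methyl, so the pair cannot separate those two differences, and two steps set no rule for the wider series.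

Still open, on these data alone, is whether a methyl two atoms from the ring nitrogen would give a step of similar size on the core of compound 3, which would separate the effect of the core from that of the place. Also open, as far as these compounds go, is how a different group at that same place, such as an amine, a carboxylic acid or a longer chain, would read in this assay on the core of compound 2 or of compound 3.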